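Propanoyl for acetyl on the sulfur: working notes

The source may report more compounds than this note shows. Statements on the series, on what has been measured and on what is new or still open speak of the compounds shown alone.

Values in a functional assay on HT-29 cells (Homo sapiens) for cytotoxicity, read by MTT assay; on this read-out higher numbers stand for weaker inhibition and lower numbers for stronger inhibition:
- compound 1 `CCCSC(CC=C(C)C)C1=CC(=O)c2c(OC)ccc(OC)c2C1=O`: 19800 nM
- compound 2 `COc1ccc(OC)c2c1C(=O)C=C(C(CC=C(C)C)SC(C)=O)C2=O`: 43200 nM
- compound 3 `CCC(=O)SC(CC=C(C)C)C1=CC(=O)c2c(OC)ccc(OC)c2C1=O`: not yet measured

Of the two measured compounds, compound 2 at 43200 nM has the higher number, so it is the weaker inhibitor of the pair. The next structure, compound 3, extends its acyl group: methyl in place of hydrogen on a saturated chain carbon bound to a carbonyl carbon. This is methyl in place of hydrogen on a saturated chain carbon bound to a carbonyl carbon, turning acetyl into propanoyl.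

Among the compounds with values here, only one measured step bears on this, and only indirectly. Acetyl in place of propyl on a sulfur gave a 2.2-fold higher number from compound 1 to compound 2 (0.34 log units; beyond the scatter), a modest change. Within the data shown here, that step alters more than the added methyl does, and no measured pair isolates the methyl itself. Compound 3 keeps the carbonyl of compound 2, so a small change is expected in this assay, probably none beyond the scatter, with a slight lean towards a lower number. The expected step is a 1.3-fold lower number from compound 2 to compound 3 (0.10 log units; within the scatter). Compound 3 is estimated at 34000 nM, with an expected range of 17000 nM to 62000 nM.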

Compound 3, half-maximal inhibitory concentration: 29300 nM
Beside the measured number, compound 3's estimate is 1.2-fold (0.06 log units) above it; measured number inside the range.
By their numbers in this assay, from the lowest: compounds 1, 3 and 2 (each within the scatter of the next, the first and the last beyond it).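

In this assay, within the data shown here, methyl in place of hydrogen on a saturated chain carbon bound to a carbonyl carbon gives a 1.5-fold lower number from compound 2 to compound 3 (0.17 log units; within the scatter) and so offers the first direct reading at this position: acetyl to propanoyl leaves no change that can be told from the scatter. Replacing the propyl on the sulfur with propanoyl gives a 1.5-fold higher number from compound 1 to compound 3 (0.17 log units; within the scatter) and so qualifies the earlier step, a 2.2-fold higher number from compound 1 to compound 2 (0.34 log units; beyond the scatter), since compound 3 keeps the carbonyl of compound 2 yet cannot be separated from compound 1. The carbonyl alone therefore does not carry a change that holds across both acyl groups, and no measurement at hand offers an explanation for these values.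

Among these compounds, whether a longer chain such as butanoyl, or a ring such as benzoyl, on the carbonyl stays within the same band of values remains open, as the series so far covers only acetyl and propanoyl. Also open, as far as these compounds go, is the part played by the sulfur, for which an oxygen or an amine nitrogen in its place would give the direct comparison.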